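Furan-3-yl in place of the hydroxylated lactone ring

A few compounds are considered here, and "the series" means these few. Any claim that something is new, unique, unknown or untested is made for them only; others in the source may bear on it.

Measured in a functional assay on HT-29 cells (Homo sapiens) for antiproliferative activity, read by XTT assay, with a stated time of 72 h; on this read-out lower numbers stand for stronger inhibition and higher numbers for weaker inhibition:
compound 1 `C=C(C)CCC[C@]1(C)C2=CCC[C@](C)(C[C@H](OC(C)=O)C3=CC(=O)OC3O)[C@H]2CC[C@H]1C`: 4200 nM
compound 2 `C=C(C)CC[C@]1(C)C2=CCC[C@](C)(C[C@@H](O)C3=CC(=O)OC3O)[C@H]2CC[C@H]1C`: 3600 nM
compound 3 `C=C(C)CC[C@]1(C)C2=CCC[C@](C)(C[C@@H](OC(C)=O)C3=CC(=O)OC3O)[C@H]2CC[C@H]1C`: 4800 nM

Compound 2, at 3600 nM, cannot be separated from compound 1 or compound 3, since all three values lie within the scatter of one another. The next compound to be read is compound 4 `C=C(C)CC[C@]1(C)C2=CCC[C@](C)(C[C@@H](O)c3ccoc3)[C@H]2CC[C@H]1C`. Its change from compound 2 is a group of 5 heavy atoms (4 carbon, 1 oxygen; one five-membered aromatic ring with 1 hetero atom) in place of a group of 7 heavy atoms (4 carbon, 3 oxygen; one five-membered non-aromatic ring with 1 hetero atom), on a saturated chain carbon bound to an oxygen on a saturated carbon and a saturated chain carbon. The hydroxyl on the saturated chain carbon stays in place.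

Within the data shown here, only one measured step bears on this, and only indirectly. The step of a 1.3-fold higher number from compound 2 to compound 3 (0.12 log units; within the scatter) is acetyl in place of hydrogen on an oxygen on a saturated carbon, and it stays within the scatter. That step shows little response in this assay at that oxygen, but it does not touch the ring that leaves. All three measured compounds carry that ring, so the series gives no direct measure of what its loss does. The direction is therefore a cautious expectation and the range is wide. An expected step of a 2.8-fold higher number from compound 2 to compound 4 (0.44 log units; beyond the scatter) is assumed, towards a higher number and so weaker inhibition. For compound 4 the estimated value is 10000 nM, with an expected range from 3000 nM to 35000 nM.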

Compound 4, half-maximal inhibitory concentration: 30000 nM
The estimate for compound 4 lay 3.0-fold (0.48 log units) below the measured number, and the stated range covers the measured number.
By their numbers in this assay, from the lowest: compounds 2, 1 and 3 (each within the scatter of the next); then compound 4.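

In this assay, among these compounds, the hydroxylated lactone ring is the first place where a change moves the number beyond the scatter: furan-3-yl in its place gives an 8.3-fold higher number from compound 2 to compound 4 (0.92 log units; beyond the scatter), towards weaker inhibition. Set against the acetyl step from the same parent, a 1.3-fold higher number from compound 2 to compound 3 (0.12 log units; within the scatter), which stays within the scatter, this position on the saturated chain carbon responds more than the oxygen on the saturated carbon, with compound 4 at 30000 nM. No supporting measurement bears on why the number rises with this replacement.

The step changes the ring type, the hydrogen-bond donor count and the hydrogen-bond acceptor count all at once, so the compounds shown cannot assign the difference to any one of these features. Also open, as far as these compounds go, is how a carboxylic acid or an amine on the same saturated chain carbon would read in this assay, and whether acetyl on the oxygen remains within the scatter when furan-3-yl is present.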